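Swapping Chloro for Hydroxy on a Growth Inhibitor

The source may report more compounds than this note shows. Statements on the series, on what has been measured and on what is new or still open speak of the compounds shown alone.

Within the data shown here, in a functional assay on MCF7 cells (Homo sapiens) for inhibition, read by MTT assay, with a stated time of 72 h (a lower number here means a stronger inhibitor of growth, a higher number a weaker inhibitor of growth), compound 3 `O=C1CC(N2C(=O)/C(=C/C(Cl)=C/c3ccc([N+](=O)[O-])cc3)SC2=S)C(=O)N1c1ccc(Cl)cc1` gives 7950 nM as the only true number so far. Compound 1 `O=C1CC(N2C(=O)CSC2=S)C(=O)N1c1ccc(Cl)cc1` reads > 100000 nM which is a limit of the assay and not a number. Compound 2 `O=C1CC(N2C(=O)CSC2=S)C(=O)N1c1ccc(O)cc1` reads > 100000 nM which is likewise a limit. Compound 4 `O=C1CC(N2C(=O)/C(=C/C(Cl)=C/c3ccc([N+](=O)[O-])cc3)SC2=S)C(=O)N1c1ccc(O)cc1` is still unmeasured and differs from compound 3 by a single change, hydroxy in place of chloro on an aromatic carbon is the full count. Among the measured compounds shown here, only one measured step bears on this, a step that the two limits leave unreadable from compound 1 to compound 2 with the same change, and its two limits hide its size. No step beyond the scatter is therefore expected in this assay in either direction. The estimated step is a 1.3-fold higher number from compound 3 to compound 4 (0.10 log units; within the scatter) for this change. For compound 4 the estimate is 10000 nM with an expected range of 3000 nM to 30000 nM in this measurement.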

Compound 4, concentration for 50% growth inhibition: 4000 nM
Beside the measured number, compound 4's estimate is 2.5-fold (0.40 log units) above it, within the range that was stated.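

In this assay, among these compounds, the change from 4-chlorophenyl to 4-hydroxyphenyl can now be read for the first time: a 2.0-fold lower number from compound 3 to compound 4 (0.30 log units; within the scatter). At this place on the ring, hydroxy can therefore stand in for chloro without a shift beyond the scatter, even though a hydrogen-bond donor and a hydrogen-bond acceptor enter with it. The same change from compound 1 to compound 2 cannot be read, since both values are limits of the assay and not numbers: the limit of > 100000 nM in this assay, at which 2 of the 4 values shown sit.

From the compounds shown here alone, whether an amine or a carboxylic acid on this aromatic carbon would also leave the number within the scatter remains open. So does the effect of a longer chain, such as an ethoxy group.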